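The compounds below may be only part of what the source reports. "The series", "measured", "known", "first", "only" and "open" are said of these compounds alone.

In a functional assay on L1210 cells (Mus musculus) for inhibition, with a stated time of 48 h (a higher number here means a weaker inhibitor, a lower number a stronger inhibitor), compound 1 `COC(=O)C[C@H](NC(=O)OC(C)(C)C)C(=O)N(Cc1ccccc1)C1(C(=O)NCc2ccccc2)CCN(Cc2ccccc2)CC1` gives 18000 nM, and compound 2 `COC(=O)C[C@H](NC(=O)OC(C)(C)C)C(=O)N(Cc1ccccc1)C1(C(=O)NC(C)(C)C)CCN(Cc2ccccc2)CC1` gives 23000 nM. Those two measurements show a 1.3-fold higher number from compound 1 to compound 2 (0.11 log units; within the scatter), so compound 1 cannot be told apart from compound 2 on these numbers. Compound 3 `COC(=O)C[C@H](NC(=O)OC(C)(C)C)C(=O)N(C1CC1)C1(C(=O)NCc2ccccc2)CCN(Cc2ccccc2)CC1` keeps the rest of compound 1 but carries cyclopropyl in place of benzyl on an amide-type nitrogen whose other neighbours are a carbonyl carbon and a saturated ring carbon: cyclopropyl in place of benzyl on an amide-type nitrogen. Among the measured compounds shown here, no measured step touches this nitrogen. For the measured compounds named here, the only guide is the swap of benzyl for tert-butyl on another amide-type nitrogen, which gave a 1.3-fold higher number from compound 1 to compound 2 (0.11 log units; within the scatter). Going by these compounds, on that thin evidence, no change beyond the scatter is expected in this assay, though the direction remains open. The expected step is a 1.4-fold higher number from compound 1 to compound 3 (0.14 log units; within the scatter). Compound 3 is estimated at 25000 nM, with an expected range of 10000 nM to 60000 nM.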

Compound 3, half-maximal inhibitory concentration: 14000 nM
Beside the measured number, compound 3's estimate is 1.8-fold (0.25 log units) above it, and the stated range covers the measured number.
By their numbers in this assay, from the lowest: compounds 3, 1 and 2 (each within the scatter of the next).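

Among the compounds shown here, compound 3 gives the first reading at the amide-type nitrogen whose other neighbours are a carbonyl carbon and a saturated ring carbon: in this assay, the swap of benzyl for cyclopropyl gives a 1.3-fold lower number from compound 1 to compound 3 (0.11 log units; within the scatter), so the two compounds cannot be told apart. At this nitrogen, therefore, a group with a six-membered aromatic ring and one with a three-membered non-aromatic ring read alike on these numbers, just as the swap on the other amide-type nitrogen, with a 1.3-fold higher number from compound 1 to compound 2 (0.11 log units; within the scatter), also stayed within the scatter. Nothing available explains why the reading holds across this swap.

Going by these compounds, whether methyl, or a chain ending in an amine or a carboxylic acid, would read any differently on this nitrogen stays open. On these data alone, it is also open whether any group at this nitrogen can move the number beyond the scatter in either direction.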